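The source may report more compounds than this note shows. Statements on the series, on what has been measured and on what is new or still open speak of the compounds shown alone.

Measured so far, all in a functional assay on OVCAR-4 cells (Homo sapiens) for inhibition; on this read-out lower numbers stand for stronger inhibition of growth and higher numbers for weaker inhibition of growth

compound 1 `Nc1ccc(-c2nc3ccc(F)cc3s2)cc1I` gives 30 nM
compound 2 `Cc1cc(-c2nc3c(F)cccc3s2)ccc1N` gives 20900 nM
compound 3 `Cc1cc(-c2nc3cccc(F)c3s2)ccc1N` gives 7400 nM

Compound 1 holds the lowest number of the three, and its gaps to compound 3 and to compound 2 both lie beyond the scatter. The next compound, compound 4 `Cc1cc(-c2nc3ccc(F)cc3s2)ccc1N`, keeps the rest of compound 1 and changes one group: methyl in place of iodo on an aromatic carbon. For the measured compounds named here, no measured pair isolates this swap, so its size in this assay has no direct precedent.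

The only indication comes from the two other compounds carrying methyl. Compound 2 stands at 20900 nM and compound 3 stands at 7400 nM, but both also differ from compound 4 elsewhere in the structure, so they guide the direction more than the size. A move toward a higher number, meaning weaker inhibition of growth, is expected, probably beyond the scatter, though not as far as those two values. The expected step is a 4.0-fold higher number from compound 1 to compound 4 (0.60 log units; beyond the scatter) in this estimate. For compound 4 the estimated value is 120 nM, with an expected range from 8 nM to 3000 nM for repeat measurements.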

Compound 4, concentration for 50% growth inhibition: 10 nM
Estimate against measurement, compound 4: 12-fold (1.08 log units) above; low and high end bracket the measured number.
By their numbers in this assay, from the lowest: compound 4; then compound 1; then compound 3; then compound 2.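

In this assay the aromatic carbon ortho to an amino group accepts methyl in place of iodo with no loss, and the change gives a 3.0-fold lower number from compound 1 to compound 4 (0.48 log units; beyond the scatter). Iodo is therefore not required on this carbon for a low number, and the lowest number so far now belongs to compound 4 (10 nM). Methyl on this carbon also cannot by itself account for the high numbers of the other two methyl compounds, since the same group is present in compound 2 (20900 nM) and compound 3 (7400 nM).

No measurement among these compounds speaks to the reason for the step from iodo to methyl. Still open, from the compounds shown here alone, is whether other groups on this carbon, such as chloro, ethyl, hydroxyl or methoxy, keep the number as low, and whether an iodo counterpart of compound 2 or compound 3 would differ from its methyl compound as compound 1 differs from compound 4.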